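Swapping the Aryl Group on a Bromo Compound

The compounds below may be only part of what the source reports. "The series", "measured", "known", "first", "only" and "open" are said of these compounds alone.

Compound 1 `O=S(=O)(/C=C/c1ccc(Cl)c(Cl)c1)Cc1ccc(Nc2ncnc3ccccc23)cc1`: 41000 nM
Compound 2 `O=S(=O)(/C=C/c1ccc(Cl)cc1Cl)Cc1ccc(Nc2ncnc3ccccc23)cc1`: 14000 nM
Compound 3 `O=S(=O)(/C=C/c1ccc(Cl)c(Cl)c1)Cc1ccc(Nc2ncnc3ccc(Br)cc23)cc1`: 5000 nM

All three values come from a functional assay on SW-620 cells (Homo sapiens) (a higher number here means a weaker inhibitor of growth, a lower number a stronger inhibitor of growth), where a lower number marks a stronger effect. Compound 3 stands lowest of the three at 5000 nM. The next compound to test, compound 4 `O=S(=O)(/C=C/c1ccc(F)cc1F)Cc1ccc(Nc2ncnc3ccc(Br)cc23)cc1`, keeps the bromo group of compound 3 and alters only the aromatic group at the end of the chain: 2,4-difluorophenyl in place of 3,4-dichlorophenyl on a double-bonded chain carbon bound to a double-bonded chain carbon.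

Two measured steps are available as guides. The bromo step, an 8.2-fold lower number from compound 1 to compound 3 (0.91 log units; beyond the scatter), bears only indirectly, as that group stays in place here. The closer guide is a 2.9-fold lower number from compound 1 to compound 2 (0.47 log units; beyond the scatter), which brought in the 2,4-dichlorophenyl group on a core without bromo. It shows a modest gain from this arrangement of the two halogens, but it was measured on a different core. Within the data shown here, no measured compound carries 2,4-difluorophenyl, and no measured step replaces chlorine with fluorine, so that part of the change remains open.

A small move towards a lower number is therefore expected, possibly no larger than the scatter. The expected change is a 1.4-fold lower number from compound 3 to compound 4 (0.15 log units; within the scatter). For compound 4 the estimated value is 3500 nM, with an expected range from 1200 nM to 11000 nM.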

Compound 4, concentration for 50% growth inhibition: 100000 nM
Estimate against measurement, compound 4: 29-fold (1.46 log units) below; measured number above the stated range.
By their numbers in this assay, from the lowest: compound 3; then compound 2; then compound 1; then compound 4.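

In this assay, the swap at this place gives a 20-fold higher number from compound 3 to compound 4 (1.30 log units; beyond the scatter). Among these compounds, the end aromatic group is therefore far from interchangeable on the bromo core, whereas the only earlier change at this place, made on the core without bromo, gave a 2.9-fold lower number from compound 1 to compound 2 (0.47 log units; beyond the scatter). The 3,4-dichlorophenyl and 2,4-difluorophenyl groups have the same count of heavy atoms, the same aromatic ring, no hydrogen-bond donors or acceptors and no net charge, so these counts do not separate them, even though the step between them is large. No available evidence bears on why the number rises.

This single step changes both the kind of halogen and where the halogens sit, so the compounds shown cannot say which of the two accounts for the rise. A 3,4-difluorophenyl group on the core of compound 3 would change the halogen alone, while a plain phenyl group would show how the bromo core behaves with no halogen on that ring.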